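Swapping the carbamate tert-butyl for a 2-fluoroethyl group

A few compounds are considered here, and "the series" means these few. Any claim that something is new, unique, unknown or untested is made for them only; others in the source may bear on it.

Measured so far:
Compound 1 `CC(C)OC(=O)N1CCC(Oc2ncnc3c2CCN3c2ccc(S(C)(=O)=O)cc2)CC1`: 154%
Compound 2 `CC(C)OC(=O)N1CCC(Oc2ncnc3c2CCN3c2ccc(-c3cccn3C)cc2F)CC1`: 44%
Compound 3 `CC(C)(C)OC(=O)N1CCC(Oc2ncnc3c2CCN3c2ccc(S(C)(=O)=O)cc2F)CC1`: 139%

All three were tested in a functional assay on CHO-K1 cells with Glucose-dependent insulinotropic receptor (Homo sapiens) as the target, read by a luciferase reporter, with a stated time of 5 h; on this read-out higher numbers stand for larger maximal responses and lower numbers for smaller maximal responses. Compound 1 gives 154%, compound 2 gives 44% and compound 3 gives 139%. Among these three numbers compound 3 stands second highest: compound 1 lies above it by a margin beyond the usual scatter, while compound 2 lies far below it, also beyond the scatter.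

The next compound, compound 4 `CS(=O)(=O)c1ccc(N2CCc3c(OC4CCN(C(=O)OCCF)CC4)ncnc32)c(F)c1`, has not yet been measured in this assay. It differs from compound 3 in one place: 2-fluoroethyl in place of tert-butyl on an oxygen next to a carbonyl group. The carbonyl group and the rest of the molecule stay the same.

Within the data shown here, no measured pair here shows what this kind of change does in this assay, so the expectation rests on compound 3 alone. A small step is expected, likely none beyond the scatter, and the estimated step is a number 9 percentage points lower from compound 3 to compound 4 (within the scatter). Compound 4 is therefore estimated at 130%, within a range from 95% to 165%.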

Compound 4, largest response reached (reported as percent of maximum), in percent of the reference or control that the assay uses: 86%
For compound 4 the middle estimate is 44 percentage points above the measured one, and the stated range ends above it.
By their numbers in this assay, from the lowest: compound 2; then compound 4; then compound 3; then compound 1.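

In this assay the group on an oxygen next to a carbonyl group turns out to matter: the swap of tert-butyl for 2-fluoroethyl gives a number 53 percentage points lower from compound 3 to compound 4 (beyond the scatter) with the rest of the molecule unchanged. Among these compounds, this is the first comparison here of two compounds that differ in one place, and it shows that this end of the molecule alone can shift the maximal response beyond the scatter. No measurement at hand gives a reason for this drop.

From the compounds shown here alone, whether the loss follows from tert-butyl leaving or from 2-fluoroethyl entering stays open, and a plain ethyl group or a longer 3-fluoropropyl chain on the same oxygen would help to separate the two. Going by these compounds, whether the swap acts alike when other parts of the molecule differ also remains open.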